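The source may hold more compounds than are shown below. What is called first, only, known or untested is meant among the compounds shown, and "the series" means these compounds.

Working notes on the shared core, read in an assay on isolated protein for displacement of a labelled ligand from sodium-dependent dopamine transporter (Homo sapiens), read by scintillation proximity assay; on this read-out higher numbers stand for weaker inhibition and lower numbers for stronger inhibition. Compound 1 `Fc1cccc(Cl)c1Oc1cccc(F)c1OC1CCNCC1` carries a piperidin-4-yl group on the oxygen on an aromatic ring. In this assay compound 1 gives > 6370 nM, which is a limit of the assay and not a number. Compound 2 `Cc1cccc(F)c1Oc1cccc(F)c1OC1CNC1` carries an azetidin-3-yl group at the same oxygen. In this assay compound 2 gives > 6460 nM, again a limit of the assay rather than a number. Among the compounds with values here, compound 2 thus stands only at a limit, and the one further value shown is also a limit, so no measured step between compounds is available and nothing orders the two. Compound 3 `Cc1cccc(F)c1Oc1cccc(F)c1OC1CCNCC1` is not yet measured and differs from compound 2 by piperidin-4-yl in place of azetidin-3-yl on an oxygen on an aromatic ring. Compound 1 already carries the piperidin-4-yl group and sits at a limit, which gives no sign that this ring brings binding into the measurable range. For compound 3 the expectation is therefore no step beyond the scatter, that is a step that the limit leaves unreadable from compound 2 to compound 3. The value expected for compound 3 is 9000 nM, within 3000 nM to 30000 nM, most likely reported again only as a limit.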

Compound 3, inhibition constant: > 6460 nM
Compound 3 was reported as a limit; the forecaster's own chance of this, stated with the estimate: 70%; the middle value lies beyond the limit too.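

Compound 1, compound 2 and compound 3 all stand at limits of the assay and not at numbers, so the steps from compound 2 to compound 3 and from compound 1 to compound 3 cannot be read. The compounds shown leave open how piperidin-4-yl compares with azetidin-3-yl, or methyl with chloro, in this assay.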